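The source may report more compounds than this note shows. Statements on the series, on what has been measured and on what is new or still open speak of the compounds shown alone.

Going by the values given here, in a functional assay on HCT-116 cells (Homo sapiens) for inhibition, read by MTT assay, with a stated time of 72 h (on this read-out higher numbers stand for weaker inhibition and lower numbers for stronger inhibition), compound 2 `Nc1ncnc2c1c(-c1cnc3[nH]ccc3c1)nn2CCCCCCC(=O)NO` gives 9860 nM, the lowest of the two numbers measured so far. Compound 1 `Nc1nc2cc(-c3nn(CCCCCCCCCC(=O)NO)c4ncnc(N)c34)ccc2o1` gives 23100 nM; its number is higher than that of compound 2 by more than the usual scatter, but compound 1 also differs from compound 2 in its core and in its chain, so no single step can be read from this pair. Compound 3 `Nc1ncnc2c1c(-c1cnc3[nH]ccc3c1)nn2CCC(=O)NO` is the next compound to be measured. It differs from compound 2 in one place (hydroxycarbamoyl in place of 4-(hydroxycarbamoyl)butyl on a saturated chain carbon, two bonds along the chain from an aromatic nitrogen). Among the compounds with values here, no measured pair shows what such a change does, so the expectation rests on the change alone. The expected step, a 3.0-fold higher number from compound 2 to compound 3 (0.48 log units; beyond the scatter), is towards a higher number, beyond the scatter. For compound 3 the estimate is 30000 nM, within a range from 8000 nM to 120000 nM.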

Compound 3, half-maximal inhibitory concentration: > 150000 nM
Compound 3 gave a limit, no number (the forecaster's own chance of this, stated with the estimate: 25%); at least 5.0-fold (0.69 log units) between middle value and limit.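

Compound 2 and compound 3 are the first pair shown that differ in one place, so the effect of the chain can now be read on its own in this assay. Putting hydroxycarbamoyl in place of 4-(hydroxycarbamoyl)butyl, on a saturated chain carbon, two bonds along the chain from an aromatic nitrogen, gives a large step, an at least 15-fold higher number from compound 2 to compound 3 (1.18 log units; beyond the scatter), even though both compounds keep the shared core and the hydroxycarbamoyl end, so this position is sensitive to the length of the chain. The result for compound 3 is a limit, not a number: the limit of > 150000 nM in this assay, at which 1 of the 3 values shown sits.

From the compounds shown here alone, what a longer chain would do on the core of compound 2 remains open, since compound 1 differs in its core as well. Also open, going by these compounds, is whether a carboxylic acid could replace the hydroxycarbamoyl end of the chain.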